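This account rests on a few compounds, and the source may have more. Where it says the series, first, only, none or still open, it means among the compounds named here.

Working notes on the series. In an ADME assay on THP-1 cells (Homo sapiens) for cytotoxicity, read by trypan blue exclusion, with a stated time of 48 h (a lower number here means a stronger inhibitor of growth, a higher number a weaker inhibitor of growth), compound 1 `Cc1cc(CNCc2ccc(Cl)cc2)c(C)n1-c1ccc(Cl)cc1` gives 18 ug/mL. Compound 2 `Cc1c(CN2CCN(C)CC2)cc(-c2ccc(Cl)cc2)n1-c1ccc(Cl)cc1` gives 3.23 ug/mL in this assay, and compound 3 `Cc1c(CNC2CCCCC2)cc(-c2ccc(Cl)cc2)n1-c1ccc(Cl)cc1` gives 3.9 ug/mL. Among the three numbers compound 2 is separated from compound 1 beyond the scatter, but not from compound 3. Going by the values given here, the only measured step bearing on the same position is a 1.2-fold higher number from compound 2 to compound 3 (0.08 log units; within the scatter), a change of the whole group on the saturated chain carbon that stayed within the scatter. Compound 4 `Cc1c(CN2CCN(C3CC4CCC3C4)CC2)cc(-c2ccc(Cl)cc2)n1-c1ccc(Cl)cc1` differs from compound 2 by a group of 7 heavy atoms (7 carbon; 2 five-membered non-aromatic rings of carbon only) in place of one carbon atom, on an amine nitrogen in a ring. Since the larger change from compound 2 to compound 3 moved nothing beyond the scatter, no step beyond the scatter is expected in this assay here either. Compound 4 is therefore expected at 3.5 ug/mL, with a range of 1.5 ug/mL to 8 ug/mL. This corresponds to an expected step of a 1.1-fold higher number from compound 2 to compound 4 (0.03 log units; within the scatter).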

Compound 4, concentration for 50% growth inhibition: 429 ug/mL
Compound 4: middle estimate off by 120-fold (2.09 log units), on the low side; the whole stated range lies below it.
By their numbers in this assay, from the lowest: compounds 2 and 3 (each within the scatter of the next); then compound 1; then compound 4.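

The amine nitrogen in the ring is a place where the number in this assay can move far: the group of 7 carbon atoms with 2 five-membered non-aromatic rings, in place of methyl, gives a 130-fold higher number from compound 2 to compound 4 (2.12 log units; beyond the scatter). Going by these compounds alone, the exchange of the whole group on the saturated chain carbon, a 1.2-fold higher number from compound 2 to compound 3 (0.08 log units; within the scatter), gave no sign of a step this large. Nothing measured on these compounds accounts for this step.

As far as these compounds go, it remains open whether an ethyl or a cyclopentyl group on that nitrogen already produces a step beyond the scatter, or whether it takes the full two-ring group.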